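Extending the alkyne chain from propyl to butyl

The source may hold more compounds than are shown below. What is called first, only, known or untested is meant among the compounds shown, and "the series" means these compounds.

Measured in a functional assay on K562 cells (Homo sapiens) for inhibition; a higher number here means a weaker inhibitor, a lower number a stronger inhibitor: compound 1 `C#Cc1cc(C)oc(=O)c1` gives 2000 nM; compound 2 `CCCC#Cc1cc(C)oc(=O)c1` gives 17800 nM.

Compound 2 holds the highest of the two numbers in this assay, and the gap to the other is an 8.9-fold higher number from compound 1 to compound 2 (0.95 log units; beyond the scatter). Compound 3 `CCCCC#Cc1cc(C)oc(=O)c1` differs from compound 2 by methyl in place of hydrogen on a saturated chain carbon, three bonds along the chain from a triple-bonded carbon. For the measured compounds named here, only one measured step bears on this change, namely an 8.9-fold higher number from compound 1 to compound 2 (0.95 log units; beyond the scatter), which installed the whole propyl chain at once. Adding a single methyl to that chain is a smaller alteration, so a further weakening is expected, but of smaller size. Compound 3 is therefore estimated at 28000 nM, with a range of 9000 nM to 90000 nM. That expectation corresponds to a 1.6-fold higher number from compound 2 to compound 3 (0.20 log units; within the scatter).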

Compound 3, half-maximal inhibitory concentration: 15500 nM
Compound 3: middle estimate off by 1.8-fold (0.26 log units), on the high side; low and high end bracket the measured number.
By their numbers in this assay, from the lowest: compound 1; then compounds 3 and 2 (each within the scatter of the next).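

In this assay the methyl added to the propyl chain gives a 1.1-fold lower number from compound 2 to compound 3 (0.06 log units; within the scatter) and so leaves no readable mark at this place, three bonds along the chain from a triple-bonded carbon. The whole butyl chain gives a 7.8-fold higher number from compound 1 to compound 3 (0.89 log units; beyond the scatter) and thus stands with the propyl chain, apart from the hydrogen of compound 1. No supporting measurement accounts for this result.

The compounds shown leave open whether a chain longer than butyl would stay level with these two. They also leave open how a methyl or an ethyl on the triple-bonded carbon, or an amine at the end of the chain, would compare.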